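Methyl on the imidazole carbon: butynyl urea series

The compounds below may be only part of what the source reports. "The series", "measured", "known", "first", "only" and "open" are said of these compounds alone.

Compound 1 `CC1CCC(=O)N1CC#CCn1ccnc1` and compound 2 `Cc1cncn1CC#CCN1C(=O)CCC1C` share a lactam-bearing core; compound 3 `CN(C)C(=O)N(C)CC#CCn1ccnc1` carries a urea instead, and the difference between the two cores is not broken down here. Compound 4 `Cc1cncn1CC#CCN(C)C(=O)N(C)C` is the still unmeasured member.

All readings come from a functional assay on the whole organism for agonist activity, with Mus musculus as the target; on this read-out lower numbers stand for an effect already at smaller amounts and higher numbers for an effect only at larger amounts of compound. For compound 1 the result is a limit of the assay, > 100 mg/kg. For compound 2 the result is likewise a limit, > 100 mg/kg. For the measured compounds named here, compound 3 is the only member with a number in this assay, giving 25.4 mg/kg.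

The change from compound 1 to compound 2 is methyl in place of hydrogen on an aromatic carbon; its step, a step that the two limits leave unreadable from compound 1 to compound 2, cannot be read, since both ends sit at the limit of > 100 mg/kg in this assay, at which 2 of the 3 values shown sit. The change from compound 3 to compound 4 is methyl in place of hydrogen on an aromatic carbon, the same change on the same place of the ring, now made on the urea core.

Going by the values given here, what the step will do on this core is therefore open: the only measured instance of the change teaches nothing about its size. The working expectation is that compound 4 stays near compound 3, with the step from compound 3 to compound 4 estimated at a 1.4-fold higher number from compound 3 to compound 4 (0.14 log units; within the scatter), and that rests only on compound 3 having a number at 25.4 mg/kg rather than a limit. Compound 4 is accordingly expected at 35 mg/kg, with a wide band from 10 mg/kg to 120 mg/kg that also allows for a limit being reported.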

Compound 4, dose for half-maximal effect: > 100 mg/kg
Compound 4 ended at the assay's limit; the forecaster's own chance of this, stated with the estimate: 25%; at least 2.8-fold (0.45 log units) between middle value and limit.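

In this assay, methyl in place of hydrogen on an aromatic carbon gives an at least 3.9-fold higher number from compound 3 to compound 4 (0.59 log units; beyond the scatter), so on the core of compound 3 this change shifts the effect to larger amounts of compound. Going by these compounds, compound 4 stands at > 100 mg/kg, which is a limit of the assay and not a number; the full size of the step therefore stays unknown. The same change from compound 1 to compound 2 cannot be read, so the compounds shown neither confirm nor refute that the step carries over from one core to the other, and no comparison of its size on the two cores is possible: the limit of > 100 mg/kg in this assay, at which 3 of the 4 values shown sit.

Hydrogen and methyl are the only groups shown on this ring carbon, so it remains open whether a chlorine atom, a hydroxymethyl group or an amine there would keep a measurable dose on the core of compound 3. Also open, on these data alone, is whether a longer chain between the ring and the core would bring the core of compound 1 within the measurable range of the assay, or would change what methyl does on either core.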